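Working notes: compound 2 to compound 3

This account rests on a few compounds, and the source may have more. Where it says the series, first, only, none or still open, it means among the compounds named here.

Measured in a functional assay on MCF7 cells (Homo sapiens) for inhibition, read by sulforhodamine B assay; a lower number here means a stronger inhibitor of growth, a higher number a weaker inhibitor of growth:
- compound 1 `CN(C)c1ccc(-c2ccc(-c3ccc(-c4nc5ccccc5[nH]4)cc3)cc2)cc1`: 41200 nM
- compound 2 `Oc1cccc2[nH]c(-c3ccc(-c4ccc(-c5ccc(C(F)(F)F)cc5)cc4)cc3)nc12`: 2310 nM

Compound 2 holds the lower of the two numbers, and its gap to compound 1 lies beyond the scatter. The next analogue, compound 3 `CN(C)c1ccc(-c2ccc(-c3ccc(-c4nc5c(O)cccc5[nH]4)cc3)cc2)cc1`, has dimethylamino in place of trifluoromethyl on an aromatic carbon, para to a large group: dimethylamino in place of trifluoromethyl on an aromatic carbon. Going by the values given here, no measured pair isolates this change, and two values cannot show which structural difference carries their gap. Compound 1, which also carries dimethylamino, gives 41200 nM, so a weaker result than compound 2 is expected, though the size is uncertain. The expected change beyond the scatter is a 3.9-fold higher number from compound 2 to compound 3 (0.59 log units; beyond the scatter). For compound 3 the estimate in this assay is 9000 nM, with an expected range of 2500 nM to 30000 nM.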

Compound 3, concentration for 50% growth inhibition: 2310 nM
The estimate for compound 3 lay 3.9-fold (0.59 log units) above the measured number, and the stated range ends above it.
By their numbers in this assay, from the lowest: compounds 2 and 3 (each within the scatter of the next); then compound 1.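

In this assay, dimethylamino in place of trifluoromethyl on an aromatic carbon, para to a large group, gives no change at the digits printed from compound 2 to compound 3 (within the scatter) and so shows that, with the hydroxy present, this position accepts either group. Hydroxy in place of hydrogen on an aromatic carbon gives an 18-fold lower number from compound 1 to compound 3 (1.25 log units; beyond the scatter) and so places the gap between the two earlier compounds with the hydroxy, not with the group at the far end. No measurement here bears on the reason for either step.

The shown compounds leave open whether a methoxy or an amine can take the place of the hydroxy and keep this gain. They also leave open whether a carboxylic acid or a chlorine on the carbon carrying dimethylamino would fit as well.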